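A few compounds are considered here, and "the series" means these few. Any claim that something is new, unique, unknown or untested is made for them only; others in the source may bear on it.

Working notes on the hydrazone series.

In a functional assay on the whole organism (strain Wistar) for inhibition, with Rattus norvegicus as the target, read by paw edema, with a stated time of 2 h, at a dose of 10 mg/kg by the intraperitoneal route (a higher number here means more inhibition at the dose given (going by the name of the read-out), a lower number less inhibition), compound 1, `O=C(N/N=C/c1ccc(Cl)cc1)c1cccnc1Nc1cccc(C(F)(F)F)c1`, gives 52.8%. Compound 2, `COc1ccc(/C=N/NC(=O)c2cccnc2Nc2cccc(C(F)(F)F)c2)cc1`, gives 42.4% in this assay. The two differ in one place: methoxy in place of chloro on an aromatic carbon. That change made a step of a number 10.4 percentage points lower from compound 1 to compound 2 (beyond the scatter), a modest step beyond the usual scatter.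

Compound 3, `CNc1ncccc1C(=O)N/N=C/c1cccc(Cl)c1`, gives 61.7% in this assay. Compound 3 and compound 1 differ in more than one place, and the difference between the two cores is not broken down here. The values of compound 3 and compound 1 lie within the scatter of each other, so nothing is said about their order. Against compound 2, compound 3 sits beyond the scatter.

Compound 4, `CNc1ncccc1C(=O)N/N=C/c1cccc(OC)c1`, is not yet measured in this assay. It differs from compound 3 in one place: methoxy in place of chloro on an aromatic carbon. Among the compounds with values here, this is the same kind of change as the one from compound 1 to compound 2, though not the same: in compound 2 the methoxy stands para to a large group, in compound 4 it stands meta to a large group. Within the data shown here, for compound 4 a step of a number 9.7 percentage points lower from compound 3 to compound 4 (within the scatter) is expected, because the same kind of change gave a number 10.4 percentage points lower from compound 1 to compound 2 (beyond the scatter) on the core of compound 1, and there is only that one earlier step to rest on. Compound 4 is thus estimated at 52% in this assay, with the expected range running from 40% to 64%.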

Compound 4, a percentage reported as inhibition, in the whole organism at one dose (the size of the read-out at that dose, not a potency): 51.5%
Beside the measured number, compound 4's estimate is 0.5 percentage points above it; the measured number falls inside the stated range.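

In this assay, putting methoxy in place of chloro on an aromatic carbon gives a number 10.2 percentage points lower from compound 3 to compound 4 (beyond the scatter) on the core of compound 3, a modest step that repeats the one seen on the core of compound 1. Within this pair of cores, the change carries over with no difference in size that can be told apart: the same change on two cores in this assay, a number 10.4 percentage points lower (beyond the scatter) from compound 1 to compound 2 and a number 10.2 percentage points lower (beyond the scatter) from compound 3 to compound 4, 0.2 percentage points apart, within the scatter of two such steps. This shows agreement across two cores only, at a single dose and time, and it gives no rule for any other core; the read-out is the size of the inhibition at that dose, not a potency, and the methoxy of compound 4 stands meta to a large group, so these two pairs do not separate the place of the group from the core that carries it.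

The compounds shown carry only chloro or methoxy on this ring, which leaves open how a fluoro, an amine, a carboxylic acid or a longer chain such as ethoxy would behave there. Also open, from the compounds shown here alone, is how the separate differences between the two cores bear on the read-out, and whether the step keeps its size at other doses or times.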